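Methyl in place of methoxy on compound 1

The compounds below may be only part of what the source reports. "The series", "measured", "known", "first", "only" and "open" are said of these compounds alone.

In a functional assay on A549 cells (Homo sapiens) for cytotoxicity, read by MTT assay, with a stated time of 48 h (a lower number here means a stronger inhibitor, a higher number a weaker inhibitor), compound 1 `COc1ccc2c(c1)C(C)=CC(C)(C)N2Cc1cn(Cc2cc3cc(OC)ccc3nc2Cl)nn1` gives 30900 nM. Among the compounds with values here, that is the higher of the two numbers measured so far, which makes compound 1 the weaker inhibitor of the pair. The other measured molecule, compound 2 `CC1=CC(C)(C)N(Cc2cn(Cc3cc4ccc(C)cc4nc3Cl)nn2)c2ccccc21`, gives 11100 nM, and the gap between the two lies beyond the usual scatter of repeated measurements.

The next molecule, compound 3 `COc1ccc2nc(Cl)c(Cn3cc(CN4c5ccc(C)cc5C(C)=CC4(C)C)nn3)cc2c1`, has not been tested yet. It differs from compound 1 in one place: methyl in place of methoxy on an aromatic carbon. The rest of the structure stays the same.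

Within the data shown here, no measured pair shows this exact change on its own, so the data offer only weak guidance. A small shift toward a lower number in this assay is expected, and it may well stay within the scatter. Among the measured compounds shown here, the only hint of direction is compound 2 at 11100 nM, a lower number than the one for compound 1. The expected change is a 1.5-fold lower number from compound 1 to compound 3 (0.19 log units; within the scatter). For compound 3 the estimated value is 20000 nM, with an expected range from 8000 nM to 50000 nM.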

Compound 3, half-maximal inhibitory concentration: 15500 nM
Beside the measured number, compound 3's estimate is 1.3-fold (0.11 log units) above it; the measured number falls inside the stated range.
By their numbers in this assay, from the lowest: compounds 2, 3 and 1 (each within the scatter of the next, the first and the last beyond it).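

In this assay, replacing this methoxy with a methyl gives a 2.0-fold lower number from compound 1 to compound 3 (0.30 log units; within the scatter), so this single change leaves the number within what repeat measurements could produce. The earlier pair differed in more than one place and could not isolate any single group, whereas this pair tests the methoxy on its own, on an aromatic carbon that is meta to a fused ring and para to a fused ring. The swap removes an oxygen and a hydrogen-bond acceptor from this spot, and the activity in this assay shows no clear loss or gain, so that oxygen does not appear to be needed here, while the other methoxy of compound 1 stays in place throughout.

Going by these compounds, with only methoxy and methyl seen on this carbon, it remains open whether an amine, a carboxylic acid, a fluorine atom or a longer chain such as butoxy would be tolerated as well. The data also offer no explanation of why the two groups fall so close together in this assay.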